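This account rests on a few compounds, and the source may have more. Where it says the series, first, only, none or still open, it means among the compounds named here.

Measured in a physicochemical assay for solubility, read by spectrophotometry, using the shake flask method, with a stated time of 2 days, at pH 6.5; a higher number here means a more soluble compound, a lower number a less soluble compound:
compound 1 `O=C(O)COc1ccc2nc(-c3cn(-c4ccc(O)cc4)nn3)ccc2c1`: 365 ug/mL
compound 2 `Oc1ccc(-n2cc(-c3ccc4cc(OCC5CCCCO5)ccc4n3)nn2)cc1`: 3.4 ug/mL
compound 3 `O=C(O)CCCOc1ccc2nc(-c3cn(-c4ccc(O)c(F)c4)nn3)ccc2c1`: 19.2 ug/mL

Compound 2 stands lowest of these three numbers. Compound 4 `OCCOc1ccc2nc(-c3cn(-c4ccc(O)cc4)nn3)ccc2c1` has not yet been measured. It carries hydroxymethyl in place of the oxan-2-yl of compound 2, on a saturated chain carbon bound to an oxygen on an aromatic ring (hydroxymethyl in place of oxan-2-yl on a saturated chain carbon bound to an oxygen on an aromatic ring). Among the compounds with values here, only one measured step changes this same place: a 110-fold lower number from compound 1 to compound 2 (2.03 log units; beyond the scatter), a large step with oxan-2-yl in place of carboxy. Within the data shown here, no measured step involves hydroxymethyl, and compound 4 carries no carboxy, so a moderate rise in this assay is expected, much smaller than that step. The expected change is a 2.9-fold higher number from compound 2 to compound 4 (0.47 log units; beyond the scatter). For compound 4 the estimated value is 10 ug/mL, with an expected range of 3 ug/mL to 35 ug/mL.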

Compound 4, solubility: 2.6 ug/mL
Compound 4: middle estimate off by 3.8-fold (0.59 log units), on the high side; the whole stated range lies above it.
By their numbers in this assay, from the lowest: compounds 4 and 2 (each within the scatter of the next); then compound 3; then compound 1.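

In this assay the exchange of oxan-2-yl for hydroxymethyl, on a saturated chain carbon bound to an oxygen on an aromatic ring, gives a 1.3-fold lower number from compound 2 to compound 4 (0.12 log units; within the scatter) and so separates neither group from the other. Carboxy alone stands apart among the three groups at this place, since hydroxymethyl in its stead gives a 140-fold lower number from compound 1 to compound 4 (2.15 log units; beyond the scatter) as a large step. No measurement offered here accounts for this result.

On these data alone, whether an amine at this place would fall with carboxy or with the other two groups stays open. So does whether a longer chain ending in carboxy, on the unchanged core of compound 1, would hold a comparably high number.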